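Compound 4: a 4-Methylpiperidin-1-yl Analogue of Compound 1

A few compounds are considered here, and "the series" means these few. Any claim that something is new, unique, unknown or untested is made for them only; others in the source may bear on it.

Compound 1 `CN(C(=S)SCc1ccc(C(=O)Nc2ccccc2N)cc1)c1cccnc1` was tested in a functional assay on A-375 cells (Homo sapiens) for antiproliferative activity, read by CCK-8 assay, with a stated time of 72 h, tested at 2 uM (a lower number here means a weaker effect, a higher number a stronger effect of the compound at the concentration tested), and gives 26.5%. Among the three measured compounds this is the lowest number, yet compound 2 `COc1ccc(N2CCN(C(=S)SCc3ccc(C(=O)Nc4ccccc4N)cc3)CC2)cc1` with 28.1% sits within the scatter of it, while compound 3 `N#Cc1ccc(N2CCN(C(=S)SCc3ccc(C(=O)Nc4ccccc4N)cc3)CC2)cc1` with 41.4% lies beyond it. For the measured compounds named here, the only measured step, a number 13.3 percentage points higher from compound 2 to compound 3 (beyond the scatter), changes a substituent on an aromatic ring and does not touch the group on the thiocarbonyl carbon. Compound 4 `CC1CCN(C(=S)SCc2ccc(C(=O)Nc3ccccc3N)cc2)CC1` differs from compound 1 as follows: 4-methylpiperidin-1-yl in place of methyl(pyridin-3-yl)amino on a thiocarbonyl carbon. Going by the values given here, no measured step bears on this change, so for compound 4 no step beyond the scatter is expected, and its value in this assay is estimated at 28%, within 14% to 42%, a step of a number 1.5 percentage points higher from compound 1 to compound 4 (within the scatter).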

Compound 4, a percentage reported as inhibition, at one concentration (the size of the read-out at that concentration, not a potency): 32.7%
The estimate for compound 4 lay 4.7 percentage points below the measured number; the measured number falls inside the stated range.
By their numbers in this assay, from the lowest: compounds 1, 2, 4 and 3 (each within the scatter of the next, the first and the last beyond it).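

At the thiocarbonyl carbon, 4-methylpiperidin-1-yl in place of methyl(pyridin-3-yl)amino gives, in this assay, a reading of a number 6.2 percentage points higher from compound 1 to compound 4 (within the scatter) and is the first step shown at this position. A non-aromatic ring without the ring's aromatic nitrogen thus stands in for the aromatic group with no change beyond the scatter. No measurement available here explains this result.

On these data alone, whether a morpholine or a dimethylamino group on the thiocarbonyl carbon would also stay within the scatter remains open. So does the part played by the methyl on the piperidine ring.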